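The source may hold more compounds than are shown below. What is called first, only, known or untested is meant among the compounds shown, and "the series" means these compounds.

Measured compounds:
compound 1, `O=C(Nc1cccc(OCc2cn(-c3ccccc3)nn2)c1)Nc1ccc(Cl)c(C(F)(F)F)c1`: 1780 nM
compound 2, `CCc1ccc(-n2cc(COc3cccc(NC(=O)Nc4ccc(Cl)c(C(F)(F)F)c4)c3)nn2)cc1`: 1950 nM

Both compounds share the same core and were tested in a functional assay on HepG2 cells (Homo sapiens) for inhibition, read by MTT assay, with a stated time of 72 h; on this read-out higher numbers stand for weaker inhibition and lower numbers for stronger inhibition. In this assay compound 1 gives 1780 nM, and compound 2 gives 1950 nM. Among the compounds with values here, the only structural change between them is an ethyl in place of hydrogen on an aromatic carbon, and that step reads a 1.1-fold higher number from compound 1 to compound 2 (0.04 log units; within the scatter). Compound 2 therefore stands alongside compound 1: of the two numbers it is the one nearer the top, but the gap to compound 1 is within the scatter, so the two cannot be told apart.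

Compound 3, `CC(C)c1ccc(-n2cc(COc3cccc(NC(=O)Nc4ccc(Cl)c(C(F)(F)F)c4)c3)nn2)cc1`, has not yet been measured. It differs from compound 2 by methyl in place of hydrogen on a saturated chain carbon bound to an aromatic carbon and a saturated chain carbon. Within the data shown here, the one step that bears on this change is the one from compound 1 to compound 2, where adding an ethyl to the same ring left the number within the scatter. Growing that ethyl into an isopropyl is a smaller change than adding the ethyl was, so the expected step is a 1.1-fold higher number from compound 2 to compound 3 (0.05 log units; within the scatter), no more than the scatter in either direction. Compound 3 is thus estimated at 2200 nM, with a likely range from 1100 nM to 4500 nM.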

Compound 3, half-maximal inhibitory concentration: 2470 nM
Estimate against measurement, compound 3: 1.1-fold (0.05 log units) below, and the stated range covers the measured number.
By their numbers in this assay, from the lowest: compounds 1, 2 and 3 (each within the scatter of the next).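

In this assay the change from ethyl to isopropyl, which turns the 4-ethylphenyl into a 4-isopropylphenyl, reads a 1.3-fold higher number from compound 2 to compound 3 (0.10 log units; within the scatter) and stays within the usual scatter of the measurement. Taken from the hydrogen of compound 1 in a single move, the full isopropyl group reads a 1.4-fold higher number from compound 1 to compound 3 (0.14 log units; within the scatter) and is also within the scatter, so adding one more carbon to this group, or going straight from hydrogen to isopropyl, shows no difference that this measurement can resolve. No measurement is at hand that would explain why the three numbers sit so close together.

Still open, going by these compounds, is whether this place stays as undemanding when the group on it is not built from carbon and hydrogen alone, such as an amine or a carboxylic acid, or when it is a longer chain. With all three compounds within the scatter of one another, the series does not yet show what kind of group here, if any, would move the number beyond the scatter in either direction.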